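The source may report more compounds than this note shows. Statements on the series, on what has been measured and on what is new or still open speak of the compounds shown alone.

Measured so far:
- compound 1 `c1ccc(COc2cccc(C3CC(c4ccc5c(c4)OCCO5)=NN3c3ccccc3)c2)cc1`: 870 nM
- compound 2 `c1ccc(N2N=C(c3ccc4c(c3)OCCO4)CC2c2ccc3ccccc3c2)cc1`: 13900 nM
- compound 3 `Clc1ccc(C2CC(c3ccc4c(c3)OCCO4)=NN2c2ccccc2)cc1`: 38600 nM

All three were tested in a functional assay on WM 266-4 cells (Homo sapiens) for antiproliferative activity, read by MTT assay, with a stated time of 24 h; on this read-out lower numbers stand for stronger inhibition of growth and higher numbers for weaker inhibition of growth. Compound 3, at 38600 nM, has the highest number of the three, so it shows the weakest inhibition of growth in this set. Compound 4 `Clc1cccc(C2CC(c3ccc4c(c3)OCCO4)=NN2c2ccccc2)c1` keeps the same atoms but joins them differently: 3-chlorophenyl in place of 4-chlorophenyl on a saturated ring carbon. For the measured compounds named here, only one measured step changes the group on that saturated ring carbon alone: a 2.8-fold higher number from compound 2 to compound 3 (0.44 log units; beyond the scatter). That step swaps a whole group, whereas here only the chlorine moves, so a smaller change seems likely. Going by the values given here, no measured pair isolates such a move, and the direction is therefore weakly supported. It leans toward a lower number, since compound 2 gives 13900 nM and compound 1 gives 870 nM, both lower than compound 3. The expected change is small: a 1.5-fold lower number from compound 3 to compound 4 (0.19 log units; within the scatter). For compound 4 the estimated value is 25000 nM, with an expected range of 9000 nM to 60000 nM.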

Compound 4, concentration for 50% growth inhibition: 1750 nM
Beside the measured number, compound 4's estimate is 14-fold (1.15 log units) above it; the whole stated range lies above it.
By their numbers in this assay, from the lowest: compounds 1 and 4 (each within the scatter of the next); then compound 2; then compound 3.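

Moving the chlorine alone, with 3-chlorophenyl in place of 4-chlorophenyl on the saturated ring carbon, gives a 22-fold lower number from compound 3 to compound 4 (1.34 log units; beyond the scatter), so this position is highly sensitive to where the chlorine sits on the phenyl ring. The order against naphthalen-2-yl also reverses: 3-chlorophenyl in its place gives a 7.9-fold lower number from compound 2 to compound 4 (0.90 log units; beyond the scatter), and chloro in place of benzyloxy on the aromatic carbon gives a 2.0-fold higher number from compound 1 to compound 4 (0.30 log units; within the scatter), so the benzyloxy group is not required to reach this level of inhibition. Nothing available explains why the place of the chlorine matters so much in this assay. Going by these compounds, it remains open whether a methoxy group, a fluorine or an amine on that same aromatic carbon would keep this level. The compounds shown also leave open whether a second chlorine on the phenyl ring would add to or lose it.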